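Sulfonyl aryl change from compound 2 to compound 3

A few compounds are considered here, and "the series" means these few. Any claim that something is new, unique, unknown or untested is made for them only; others in the source may bear on it.

In an ADME assay on microsomes from liver (Mus musculus) for metabolic stability, with a stated time of 10 min (on this read-out higher numbers stand for a more stable compound and lower numbers for a less stable compound), compound 1 `O=C(O)[C@H]1CC[C@H](C(=O)N2CC[C@](c3ccc(C(F)(C(F)(F)F)C(F)(F)F)cc3)(S(=O)(=O)c3ccc(Cl)cc3)C2)CC1` gives 100% and compound 2 `COc1ccc(S(=O)(=O)[C@@]2(c3ccc(C(F)(C(F)(F)F)C(F)(F)F)cc3)CCN(C(=O)[C@H]3CC[C@H](C(=O)O)CC3)C2)cc1` gives 98%. These two values lie within the scatter of each other, so compound 2 stands level with compound 1, and nearly all of the compound remains in both cases.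

Compound 3 `Cc1cc(S(=O)(=O)[C@@]2(c3ccc(C(F)(C(F)(F)F)C(F)(F)F)cc3)CCN(C(=O)[C@H]3CC[C@H](C(=O)O)CC3)C2)ccc1F` keeps the shared core of compound 2 and differs in one group: 4-fluoro-3-methylphenyl in place of 4-methoxyphenyl on a sulfonyl sulfur. In words, this is 4-fluoro-3-methylphenyl in place of 4-methoxyphenyl on a sulfonyl sulfur.

Going by the values given here, only one measured step bears on this change: a number 2 percentage points lower from compound 1 to compound 2 (within the scatter), with methoxy in place of chloro on an aromatic carbon. That step also concerns the 4-methoxyphenyl group that leaves here, and it stays within the scatter. Among the compounds with values here, no measured compound carries the 4-fluoro-3-methylphenyl group, so the evidence is thin and the range is kept wide on the lower side.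

On the strength of that single step, no change beyond the scatter is expected in this assay. The expected size is an estimated a number 3 percentage points lower from compound 2 to compound 3 (within the scatter). For compound 3 the estimated value is 95%, with an expected range from 82% to 100%.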

Compound 3, percent of the compound remaining: 84%
For compound 3 the middle estimate is 11 percentage points above the measured one; the range from low to high includes it.
By their numbers in this assay, from the lowest: compound 3; then compounds 2 and 1 (each within the scatter of the next).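

Notes on the aryl group on the sulfonyl sulfur: in this assay this position is not indifferent to the group it carries. The earlier swap of chloro for methoxy stayed within the scatter (a number 2 percentage points lower from compound 1 to compound 2 (within the scatter)), but the 4-fluoro-3-methylphenyl group gives a clear loss against both earlier aryl groups (a number 14 percentage points lower from compound 2 to compound 3 (beyond the scatter)) and (a number 16 percentage points lower from compound 1 to compound 3 (beyond the scatter)), although compound 3 still keeps most of the compound at 84% after the stated time. Nothing shown accounts for this loss, and no measurement at hand bears on why the read-out moves with this aryl change.

Going by these compounds, it remains open whether the step follows the fluoro or the methyl part of the new group, and 4-fluorophenyl or 3-methylphenyl on the sulfonyl sulfur would separate the two. Also open, on these data alone, is how far the read-out at this position would move with an amine on the aryl ring, as in 4-(dimethylamino)phenyl, or with a longer chain, as in 4-ethoxyphenyl or 4-butylphenyl.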